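One More Carbon on the Ester Chain

The compounds below may be only part of what the source reports. "The series", "measured", "known", "first", "only" and "open" are said of these compounds alone.

Compound 1 `CCCCCCCOC(=O)CCC(=O)N1CCN(CCCOc2cc3c(Nc4ccc(F)c(Cl)c4)ncnc3cc2OC)CC1` gives 27.2% in a functional assay on A549 cells (Homo sapiens) for cytotoxicity, read by MTT assay, with a stated time of 24 h, tested at 80 uM; a higher number here means a weaker effect of the compound at the concentration tested, a lower number a stronger effect.
Compound 2 `CCCCCCCCOC(=O)CCC(=O)N1CCN(CCCOc2cc3c(Nc4ccc(F)c(Cl)c4)ncnc3cc2OC)CC1` gives 21.7% in this assay.
Compound 3 `CCCCCCCCCCCOC(=O)CCC(=O)N1CCN(CCCOc2cc3c(Nc4ccc(F)c(Cl)c4)ncnc3cc2OC)CC1` gives 2.8% in this assay.

The change from compound 1 to compound 2 is methyl in place of hydrogen on a saturated chain carbon, seven bonds along the chain from an oxygen next to a carbonyl group and made a step of a number 5.5 percentage points lower from compound 1 to compound 2 (within the scatter). Compound 4 `CCCCCCCCCCCCOC(=O)CCC(=O)N1CCN(CCCOc2cc3c(Nc4ccc(F)c(Cl)c4)ncnc3cc2OC)CC1` arises from compound 3 by the same kind of change, (methyl in place of hydrogen on a saturated chain carbon, ten or more bonds along the chain from an oxygen next to a carbonyl group), but at a different place along the chain, as the two descriptions tell. The cores differ by butyl in place of hydrogen on a saturated chain carbon, seven bonds along the chain from an oxygen next to a carbonyl group, a change that gave a number 24.4 percentage points lower from compound 1 to compound 3 (beyond the scatter). Since compound 3 already sits close to zero with 2.8%, little room remains to fall further; the expected step is a number 0.3 percentage points lower from compound 3 to compound 4 (within the scatter). Compound 4 is therefore estimated at 2.5%, between 0% and 12%.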

Compound 4, a percentage reported as activity, at one concentration (the size of the read-out at that concentration, not a potency): 2.3%
Compound 4: middle estimate off by 0.2 percentage points, on the high side; low and high end bracket the measured number.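

Methyl in place of hydrogen gives a number 0.5 percentage points lower from compound 3 to compound 4 (within the scatter), and the same kind of change on the shorter chain behaves no differently: the same change on two cores in this assay, a number 5.5 percentage points lower (within the scatter) from compound 1 to compound 2 and a number 0.5 percentage points lower (within the scatter) from compound 3 to compound 4, 5 percentage points apart, within the scatter of two such steps. Butyl in place of hydrogen gives a number 19.4 percentage points lower from compound 2 to compound 4 (beyond the scatter), and this change also carries over from one chain length to another: the same change on two cores in this assay, a number 24.4 percentage points lower (beyond the scatter) from compound 1 to compound 3 and a number 19.4 percentage points lower (beyond the scatter) from compound 2 to compound 4, 5 percentage points apart, within the scatter of two such steps. Pentyl in place of hydrogen gives a number 24.9 percentage points lower from compound 1 to compound 4 (beyond the scatter), but these few steps at a single concentration give no potency and do not show that the changes would carry over to cores outside this short set of esters.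

Going by these compounds, it remains open whether a longer chain than that of compound 4 would give a similar number in this assay. The same question stands for a chain ending in a carboxylic acid or an amine.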